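Replacing an Anilino Group with Pyrimidin-5-ylamino

The source may hold more compounds than are shown below. What is called first, only, known or untested is meant among the compounds shown, and "the series" means these compounds.

Going by the values given here, compound 3, `C[C@@H](Cn1ccc(-c2ccc(C#N)c(Cl)c2)n1)Nc1ccccc1`, is the only member of this small set that returns a number in an ADME assay on PC-3 cells (Homo sapiens) for cytotoxicity, read by CCK-8 assay, with a stated time of 6 days (a higher number here means a weaker inhibitor, a lower number a stronger inhibitor), where compound 3 gives 3210 nM. Compound 1, `C[C@@H](Cn1ccc(-c2ccc(C#N)c(Cl)c2)n1)NC(=O)C1CC(=O)C1`, reaches only a limit of the assay, giving > 30000 nM. Compound 2, `C[C@@H](Cn1ccc(-c2ccc(C#N)c(Cl)c2)n1)NS(=O)(=O)c1cccnc1`, likewise stops at a limit, giving > 30000 nM. The two steps that lead to compound 3 are therefore read only as lower bounds: an at least 9.3-fold lower number from compound 1 to compound 3 (0.97 log units; beyond the scatter) and an at least 9.3-fold lower number from compound 2 to compound 3 (0.97 log units; beyond the scatter), while a step that the two limits leave unreadable from compound 1 to compound 2 is not readable, as both ends sit at the limit of > 30000 nM in this assay, at which 2 of the 3 values shown sit.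

Compound 4, `C[C@@H](Cn1ccc(-c2ccc(C#N)c(Cl)c2)n1)Nc1cncnc1`, differs from compound 3 by pyrimidin-5-yl in place of phenyl on an amine nitrogen. Among the compounds with values here, none of the measured steps exchanges one aromatic ring for another on that nitrogen; the two readable steps replace an acyl or sulfonyl group with phenyl, so they show only that compound 3 is the one compound with a measurable number, not how a heteroaryl ring would behave in its place. Within the data shown here, with no step that bears on this change, compound 4 is expected to stay near compound 3, and any shift is estimated to be modest, a 1.9-fold higher number from compound 3 to compound 4 (0.27 log units; within the scatter), with the direction open. Compound 4 is thus estimated at 6000 nM, within a range of 1500 nM to 30000 nM.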

Compound 4, half-maximal inhibitory concentration: > 30000 nM
Compound 4 was reported as a limit (the forecaster's own chance of this, stated with the estimate: 25%); at least 5.0-fold (0.69 log units) between middle value and limit.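

Pyrimidin-5-yl in place of phenyl on the amine nitrogen gives an at least 9.3-fold higher number from compound 3 to compound 4 (0.97 log units; beyond the scatter) in this assay, which shows that this position responds to the make-up of the aromatic ring itself, even though both groups count the same number of heavy atoms. The earlier steps shown here set phenyl against an acyl or a sulfonyl group, whereas this step keeps an aromatic ring on that nitrogen and changes only the ring, and the measurable number of compound 3 is lost. Going by these compounds alone, the steps from compound 1 and from compound 2 to compound 4 cannot be read, and compound 3 remains the only compound with a number, the others resting on a shared limit: the limit of > 30000 nM in this assay, at which 3 of the 4 values shown sit.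

The compounds shown leave open whether a pyridin-3-yl ring or a methoxyphenyl group set directly on the amine nitrogen would keep a number like that of compound 3 or would also reach the limit. They also do not tell how far past the limit compound 4 lies, and they give no order among compound 1, compound 2 and compound 4.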